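A few compounds are considered here, and "the series" means these few. Any claim that something is new, unique, unknown or untested is made for them only; others in the source may bear on it.

Compound 1 `CCNCCCNCCCCN` and compound 2 `CCNCCCCNCCCN` are built from the same atoms joined differently; the difference between the two cores is not broken down here. In a functional assay on L1210 cells (Mus musculus) for inhibition, with a stated time of 48 h (a higher number here means a weaker inhibitor, a lower number a stronger inhibitor), compound 1 gives > 100000 nM, which is a limit of the assay and not a number. Compound 2 gives > 100000 nM, likewise a limit. Compound 3 `CCCNCCCNCCCCN` carries the change methyl in place of hydrogen on a saturated chain carbon, two bonds along the chain from an amine nitrogen on the core of compound 1, and in this assay compound 3 gives > 100000 nM, again a limit. The step that the two limits leave unreadable from compound 1 to compound 3 therefore cannot be read. Compound 4 `CCCNCCCCNCCCN` carries the same change, (methyl in place of hydrogen on a saturated chain carbon, two bonds along the chain from an amine nitrogen), on the core of compound 2. Since all three values sit at the limit of > 100000 nM in this assay, at which 3 of the 3 values shown sit, the expected step is a step that the limit leaves unreadable from compound 2 to compound 4. Compound 4 is estimated to give 150000 nM in this assay, most probably reported once more only as a limit.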

Compound 4, half-maximal inhibitory concentration: > 100000 nM
Compound 4: no number, only a limit; the forecaster's own chance of this, stated with the estimate: 85%; the middle value lies beyond the limit too.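

Compound 2 and compound 4 both give only a limit, not a number, so no step can be read between them. The compounds shown leave open how strongly any of them inhibits, and whether methyl in place of hydrogen changes that at all.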